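Fluoro on the 4-methylphenyl: compound 4 against compound 1

A few compounds are considered here, and "the series" means these few. Any claim that something is new, unique, unknown or untested is made for them only; others in the source may bear on it.

Compound 1 `Cc1ccc(S(=O)(=O)c2cnc3ccc(F)cc3c2N2CCC(C)CC2)cc1` stands second highest of the three numbers at hand. In an assay on isolated protein for displacement of a labelled ligand from metabotropic glutamate receptor 5 (Homo sapiens), with a stated time of 60 min, tested at 1 uM (a lower number here means less inhibition, a higher number more inhibition at the concentration tested (going by the name of the read-out)), compound 1 gives 91%. Going by the values given here, its nearest neighbour is compound 2 `Cc1ccc(S(=O)(=O)c2cnc3ccc(Cl)cc3c2N2CCC(C)CC2)cc1`, which in this assay gives 95%; the one single-point step measured in this set, a number 4 percentage points higher from compound 1 to compound 2 (within the scatter), lies within the scatter. Furthest off is compound 3 `COc1ccc2ncc(S(=O)(=O)c3ccc(OC)c(Cl)c3)c(N3CCC(C)CC3)c2c1`, which in this assay gives 21%, a gap beyond the scatter, though compound 3 differs from compound 1 in more than one place and no step is defined between them.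

Compound 4 `Cc1ccc(S(=O)(=O)c2cnc3ccc(F)cc3c2N2CCC(C)CC2)cc1F` has not been measured. It differs from compound 1 by fluoro in place of hydrogen on an aromatic carbon. Among the compounds with values here, no measured step touches the same place: the step from compound 1 to compound 2 swaps a halogen on the shared core, not on the 4-methylphenyl, and its size says nothing direct about the 4-methylphenyl to 3-fluoro-4-methylphenyl change. Within the data shown here, the only guide is that compound 1 already gives 91% in this assay, which leaves little room upward on this read-out. Compound 4 is therefore expected to stay close to compound 1, with an expected step of a number 2 percentage points lower from compound 1 to compound 4 (within the scatter), within the scatter. The estimate for compound 4 is 89%, with a range from 76% to 97%.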

Compound 4, a percentage reported as inhibition, at one concentration (the size of the read-out at that concentration, not a potency): 86%
Beside the measured number, compound 4's estimate is 3 percentage points above it, and the stated range covers the measured number.
By their numbers in this assay, from the lowest: compound 3; then compounds 4, 1 and 2 (each within the scatter of the next).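

In this assay, fluoro in place of hydrogen on the aromatic carbon ortho to a methyl group gives a number 5 percentage points lower from compound 1 to compound 4 (within the scatter), so this change on the 4-methylphenyl leaves the read-out within the usual scatter. Going by these compounds alone, this is the first single-place reading on this ring, as the step of a number 4 percentage points higher from compound 1 to compound 2 (within the scatter) concerns a halogen on the shared core, and the two steps together show that compound 2 and compound 4 each remain within the scatter of compound 1. No supporting evidence is available to explain the result at this position.

Open, going by these compounds, is whether a group other than fluoro at this aromatic carbon, such as a nitrile, an amine or a carboxylic acid, would also keep the read-out within the scatter of compound 1, or whether this holds for fluoro only. Also open, on these data alone, is whether compound 1 and compound 4 would still match at a lower concentration, since a percentage at one concentration gives the size of the read-out there and not a potency.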